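The source may report more compounds than this note shows. Statements on the series, on what has been measured and on what is new or still open speak of the compounds shown alone.

Measured in a functional assay on A549 cells (Homo sapiens) for cytotoxicity, read by MTT assay, with a stated time of 72 h; on this read-out higher numbers stand for weaker inhibition and lower numbers for stronger inhibition:
- compound 1 `CN1CCCCC1CCO/N=C1C(=C2/C(=O)Nc3ccccc32)/Cc2ccccc2/1`: 1210 nM
- compound 2 `CN(C)CCCO/N=C1C(=C2/C(=O)Nc3ccccc32)/Nc2ccccc2/1`: 610 nM
- compound 3 `CN1CCCC1CCO/N=C1C(=C2/C(=O)Nc3ccccc32)/Nc2ccccc2/1`: 260 nM

Compound 2, at 610 nM, lies within the usual scatter of compound 1, so the two cannot be ranked. Compound 3 is clearly separated, as shown by a 2.3-fold lower number from compound 2 to compound 3 (0.37 log units; beyond the scatter).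

The next change leads to compound 4 `CN1CCC(O/N=C2C(=C3/C(=O)Nc4ccccc43)/Nc3ccccc3/2)CC1`: 1-methylpiperidin-4-yl in place of 3-(dimethylamino)propyl on an oxygen. Here, 1-methylpiperidin-4-yl stands in place of 3-(dimethylamino)propyl on an oxygen. For the measured compounds named here, no measured step makes this exact exchange. The closest is the modest 2.3-fold lower number from compound 2 to compound 3 (0.37 log units; beyond the scatter), which also replaces an open-chain dimethylamino end with a ring carrying the methylated nitrogen. Compound 1 also carries a ring, but its core differs from that of compound 2, so it offers no direct comparison. A small move towards a lower number is therefore expected in this assay, though it may not clear the scatter. The estimate is a 1.4-fold lower number from compound 2 to compound 4 (0.13 log units; within the scatter). For compound 4, the expected value is 450 nM, with an estimated range of 180 nM to 1100 nM.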

Compound 4, half-maximal inhibitory concentration: 190 nM
Compound 4: the middle estimate sits 2.4-fold (0.37 log units) above what was measured; the measured number falls inside the stated range.
By their numbers in this assay, from the lowest: compounds 4 and 3 (each within the scatter of the next); then compounds 2 and 1 (each within the scatter of the next).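

In this assay, the change on the oxygen gives a 3.2-fold lower number from compound 2 to compound 4 (0.51 log units; beyond the scatter), so 1-methylpiperidin-4-yl, a ring group without the ethyl link that compound 3 keeps, clearly separates from the open-chain 3-(dimethylamino)propyl. The two ring groups cannot be told apart, with a 1.4-fold lower number from compound 3 to compound 4 (0.14 log units; within the scatter). Among compounds 2, 3 and 4, which share one core, both ring-bearing groups therefore give lower numbers than the open chain, and that link on the oxygen is not needed for this. Nothing available explains this difference. As far as these compounds go, it remains open whether a piperidin-4-yl group without the methyl on its nitrogen, or a morpholine ring, would match compound 4. From the compounds shown here alone, it is also open whether 1-methylpiperidin-4-yl would act in the same way on the core of compound 1.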